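This account rests on a few compounds, and the source may have more. Where it says the series, first, only, none or still open, it means among the compounds named here.

In an ADME assay on a cell-free system (plasma, Rattus norvegicus) for metabolic stability (a lower number here means that the compound disappears faster, a higher number that the compound lasts longer), compound 1 `CC(C)OC[C@H](Oc1ncnc2c1cnn2-c1ncccc1Cl)C(=O)Nc1ccc(Cl)cn1` gives 0.233 h and compound 2 `CC(C)OC[C@H](Oc1ncnc2c1cnn2-c1ncccc1Cl)C(=O)Nc1ccc(C#N)cn1` gives 0.367 h on the same core, two numbers that lie within the usual scatter of each other. Compound 2 therefore stands level with compound 1 and serves as the reference for what follows. Compound 3 `N#Cc1ccc(NC(=O)[C@H](COCCO)Oc2ncnc3c2cnn3-c2ncccc2Cl)nc1` differs from it in one side chain, by the change 2-hydroxyethyl in place of isopropyl on an oxygen on a saturated carbon in which 2-hydroxyethyl takes the place of isopropyl on an oxygen on a saturated carbon. Among the measured compounds shown here, the only measured step of a 1.6-fold higher number from compound 1 to compound 2 (0.20 log units; within the scatter) is a cyano in place of chloro on an aromatic carbon. For the measured compounds named here, that step lies within the scatter and is a different change at a different place, so no measured step gives a direction for the new one. In this assay no step beyond the scatter is expected, and the estimated step is a 1.2-fold higher number from compound 2 to compound 3 (0.09 log units; within the scatter) on this thin evidence. For compound 3 the estimate is 0.45 h and the range expected runs from 0.15 h up to 1.2 h on repeat measurement.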

Compound 3, half-life: 1.92 h
Compound 3: the middle estimate sits 4.3-fold (0.63 log units) below what was measured; the measured number lies above the stated range.
By their numbers in this assay, from the lowest: compounds 1 and 2 (each within the scatter of the next); then compound 3.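

In this assay, the group on the oxygen on a saturated carbon proves to matter: 2-hydroxyethyl in place of isopropyl gives a 5.2-fold higher number from compound 2 to compound 3 (0.72 log units; beyond the scatter), whereas the earlier change of chloro to cyano on an aromatic carbon, a 1.6-fold higher number from compound 1 to compound 2 (0.20 log units; within the scatter), revealed nothing about this position. The two groups have the same count of 3 heavy atoms, so this step comes with no change in that count; the differences listed between them are one carbon exchanged for an oxygen and the appearance of a hydrogen-bond donor and a hydrogen-bond acceptor that isopropyl lacks. No measurement at hand bears on why the number rises, so the step stands as an observation without an explanation.

The compounds shown leave open whether the terminal hydroxyl is what counts, since 2-methoxyethyl, a longer chain such as 3-hydroxypropyl or an amine at the end of the chain would each separate that group from the chain itself. They also leave open whether 2-hydroxyethyl would give a similar step with chloro in place of cyano, as in compound 1.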